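This account rests on a few compounds, and the source may have more. Where it says the series, first, only, none or still open, it means among the compounds named here.

Working notes on the series. Compound 1 `CCCCCCCCCCc1ccc(-c2noc(CCCN)n2)cc1` carries the shared core with a 3-aminopropyl chain and in an assay on HeLa cells for inhibition of sphingosine-1-phosphate transporter SPNS2 (Mus musculus), read by LC-MS, tested at 2 uM (on this read-out higher numbers stand for more inhibition at the one concentration tested (going by the name of the read-out) and lower numbers for less inhibition), compound 1 gives 67%. Compound 2 `CCCCCCCCCCc1ccc(-c2noc(CC[C@@H](N)C(=O)O)n2)cc1` adds a carboxy to that chain, and in this assay compound 2 gives 5%; the step is a number 62 percentage points lower from compound 1 to compound 2 (beyond the scatter). Compound 3 `CCCCCCCCCCc1ccc(-c2noc(CC(O)CN)n2)cc1` instead adds a hydroxy, and in this assay compound 3 gives 59%. The step of a number 8 percentage points lower from compound 1 to compound 3 (within the scatter) sits within the scatter, whereas a number 54 percentage points higher from compound 2 to compound 3 (beyond the scatter) is large. Compound 3 therefore stands second highest of the three numbers, indistinguishable from compound 1 and far above compound 2.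

Compound 4 `CCCCCCCCCCc1ccc(-c2noc(CCCN3CCCCC3)n2)cc1` changes compound 3 by 2-(piperidin-1-yl)ethyl in place of 2-amino-1-hydroxyethyl on a saturated chain carbon bound to an aromatic carbon. Of the measured steps, only the hydroxy step from compound 1 to compound 3 bears directly, and it was within the scatter, so losing the hydroxy should cost little. Among the compounds with values here, no measured step covers the replacement of the amine nitrogen's hydrogens by the piperidine ring, so that part is untested; the carboxy step is not relevant here. The expected step of a number 4 percentage points lower from compound 3 to compound 4 (within the scatter) is therefore small and without a clear direction, with wide uncertainty. Compound 4 is estimated at 55%, in the range 25% to 80%.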

Compound 4, a percentage reported as inhibition, at one concentration (the size of the read-out at that concentration, not a potency): 0%
Estimate against measurement, compound 4: 55 percentage points above; the whole stated range lies above it.
By their numbers in this assay, from the lowest: compounds 4 and 2 (each within the scatter of the next); then compounds 3 and 1 (each within the scatter of the next).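

In this assay, the sharpest reading at the end of the chain is piperidin-1-yl in place of amino, on the saturated chain carbon three bonds along the chain from an aromatic carbon: a number 67 percentage points lower from compound 1 to compound 4 (beyond the scatter), so this position, where the added hydroxy of compound 3 left the number within the scatter of compound 1, does not accept this ring on the nitrogen. The other two steps fit that reading: the comparison with the hydroxy compound gives a number 59 percentage points lower from compound 3 to compound 4 (beyond the scatter), of similar size, while a number 5 percentage points lower from compound 2 to compound 4 (within the scatter) sets the piperidine compound level with the carboxy compound, so two unlike changes on this chain end at the same low numbers. Nothing available here explains why the piperidin-1-yl ring has this effect.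

Still open, as far as these compounds go, is whether the loss follows any substitution on the nitrogen or this ring in particular: a methylamino or dimethylamino group, or a pyrrolidin-1-yl ring, on the same propyl chain would separate the two. A piperidin-4-yl group, which keeps the ring but leaves a hydrogen on its nitrogen, would test the same question from the other side.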